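Isopropyl in Place of the Urea Hydrogen of Compound 2

A few compounds are considered here, and "the series" means these few. Any claim that something is new, unique, unknown or untested is made for them only; others in the source may bear on it.

In a functional assay on SMMC-7721 cells (Homo sapiens) for cytotoxicity, read by MTT assay, with a stated time of 72 h (a lower number here means a stronger inhibitor, a higher number a weaker inhibitor), compound 1 `CC(C)NC(=O)N1CCN(C(=S)SCc2cn(Cc3ccccc3F)nn2)CC1` gives 7130 nM. Compound 2 `NC(=O)N1CCN(C(=S)SCc2cn(Cc3ccc(Cl)cc3)nn2)CC1` returns only a limit in this assay, > 128000 nM, so it stands at the limit of > 128000 nM in this assay, at which 1 of the 2 values shown sits, rather than at a number. Compound 3 `CC(C)NC(=O)N1CCN(C(=S)SCc2cn(Cc3ccc(Cl)cc3)nn2)CC1` differs from compound 2 by isopropyl in place of hydrogen on an amide-type nitrogen. Going by the values given here, no measured step of this kind exists here; the two values of compound 1 and compound 2 show only that the isopropylcarbamoyl compound sits well inside the measurable range while the carbamoyl compound does not. A large step toward stronger inhibition is therefore expected, an at least 10-fold lower number from compound 2 to compound 3 (1.02 log units; beyond the scatter). Compound 3 is estimated at 12000 nM, within 3000 nM to 50000 nM.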

Compound 3, half-maximal inhibitory concentration: > 128000 nM
Compound 3: only a limit was reported (the forecaster's own chance of this, stated with the estimate: 20%); middle value at least 10-fold (1.02 log units) from the limit.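

With the isopropylcarbamoyl group held constant, the 2-fluorophenyl group of compound 1 gives way to the 4-chlorophenyl group of compound 3, and this assay shows an at least 17-fold higher number from compound 1 to compound 3 (1.25 log units; beyond the scatter). So isopropyl on the amide-type nitrogen does not by itself give a measurable value. Compound 2 and compound 3 both stand at a limit, so the step between them cannot be read: the limit of > 128000 nM in this assay, at which 2 of the 3 values shown sit.

Still open, as far as these compounds go, is whether a 4-fluorophenyl group would restore a measurable value. Also open, from the compounds shown here alone, is how a cyclohexyl group or a longer chain on that nitrogen would read.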